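Replacing pentan-3-yl with phenyl on a saturated chain carbon

A few compounds are considered here, and "the series" means these few. Any claim that something is new, unique, unknown or untested is made for them only; others in the source may bear on it.

Compound 1 `CCCCCCOc1cccc(O)c1C(=O)/C=C/c1ccc(O)cc1`: > 30000 nM (a limit of the assay)
Compound 2 `CCC(CC)COc1cccc(O)c1C(=O)/C=C/c1ccc(O)cc1`: 3390 nM

Within the data shown here, in a functional assay on PC-3 cells (Homo sapiens) for antiproliferative activity, read by sulforhodamine B assay (on this read-out lower numbers stand for stronger inhibition of growth and higher numbers for weaker inhibition of growth), compound 2 gives 3390 nM, the only actual number so far. The result for compound 1 is a limit of the assay. Compound 3 `O=C(/C=C/c1ccc(O)cc1)c1c(O)cccc1OCc1ccccc1` differs from compound 2 by phenyl in place of pentan-3-yl on a saturated chain carbon bound to an oxygen on an aromatic ring. Among the measured compounds shown here, one measured step bears on this place, an at least 8.8-fold lower number from compound 1 to compound 2 (0.94 log units; beyond the scatter), with pentan-3-yl in place of pentyl. As far as these compounds go, that step rests on (the limit of > 30000 nM in this assay, at which 1 of the 2 values shown sits), so its full size stays open. For the measured compounds named here, it shows that this place can move the read-out strongly, but no measured compound carries a ring here. A modest move toward weaker inhibition of growth is therefore expected, though it may stay within the scatter. The expected change is a 1.8-fold higher number from compound 2 to compound 3 (0.25 log units; within the scatter). In this assay compound 3 is estimated at 6000 nM, with an expected range of 2000 nM to 20000 nM.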

Compound 3, concentration for 50% growth inhibition: > 30000 nM
Compound 3: no number, only a limit (the forecaster's own chance of this, stated with the estimate: 15%); at least 5.0-fold (0.69 log units) between middle value and limit.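

In this assay, phenyl in place of pentan-3-yl on the saturated chain carbon gives an at least 8.8-fold higher number from compound 2 to compound 3 (0.94 log units; beyond the scatter), so this ring does not keep the growth inhibition seen with compound 2. Compound 3 gives > 30000 nM, which is a limit of the assay. Of the three compounds, only compound 2, with its 2-ethylbutoxy group, has a readable number, while the step from compound 1 to compound 3 cannot be read and the full size of the step to compound 3 stays open: the limit of > 30000 nM in this assay, at which 2 of the 3 values shown sit.

The compounds shown leave open whether a saturated ring such as cyclohexyl at this place would give a readable number. They also leave open whether a shorter branched chain such as isopropyl, or a phenyl carrying an amine or a carboxylic acid, would do so.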